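Phenyl in Place of Methyl on a Second Core

The source may report more compounds than this note shows. Statements on the series, on what has been measured and on what is new or still open speak of the compounds shown alone.

Measured in a functional assay on MCF7 cells (Homo sapiens) for antiproliferative activity, read by sulforhodamine B assay, with a stated time of 48 h (on this read-out lower numbers stand for stronger inhibition of growth and higher numbers for weaker inhibition of growth), so far:
compound 1, `CN1CCN(CCCNc2ccnc3cc(Cl)ccc23)CC1`: 17100 nM
compound 2, `Clc1ccc2c(NCCCN3CCN(c4ccccc4)CC3)ccnc2c1`: 12800 nM
compound 3, `CN1CCN(CCCNc2ccnc3cc(C(F)(F)F)ccc23)CC1`: 30800 nM

Compound 3 gives the highest of the three numbers in this assay. Its nearest neighbour is compound 1, whose number is lower by a 1.8-fold higher number from compound 1 to compound 3 (0.26 log units; within the scatter) read in reverse, a gap within the scatter; compound 2 is furthest away, and that gap lies beyond the scatter.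

Compound 4, `FC(F)(F)c1ccc2c(NCCCN3CCN(c4ccccc4)CC3)ccnc2c1`, follows from compound 3 by one change: phenyl in place of methyl on an amine nitrogen in a ring. The same exchange has been made once before, on the core that carries chloro rather than trifluoromethyl, and there it gave a 1.3-fold lower number from compound 1 to compound 2 (0.13 log units; within the scatter), a step within the scatter. Going by the values given here, the only step that bears on the new pair is therefore a small one, and compound 4 is expected to sit close to compound 3 in this assay, at most slightly lower: a 1.3-fold lower number from compound 3 to compound 4 (0.11 log units; within the scatter). Compound 4 is estimated at 24000 nM, with a range from 11000 nM to 55000 nM.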

Compound 4, concentration for 50% growth inhibition: 8750 nM
Compound 4: middle estimate off by 2.7-fold (0.44 log units), on the high side; measured number outside the range, below it.
By their numbers in this assay, from the lowest: compounds 4, 2, 1 and 3 (each within the scatter of the next, the first and the last beyond it).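

On the core that carries trifluoromethyl, phenyl in place of methyl on the amine nitrogen in the ring gives a 3.5-fold lower number from compound 3 to compound 4 (0.55 log units; beyond the scatter) in this assay and so leaves the scatter, which the same change on the chloro core did not do. The two cores still cannot be told apart, as the gap between the two steps stays within what such pairs allow: the same change on two cores in this assay, a 1.3-fold lower number (0.13 log units; within the scatter) from compound 1 to compound 2 and a 3.5-fold lower number (0.55 log units; beyond the scatter) from compound 3 to compound 4, 2.6-fold (0.42 log units) apart, within the scatter of two such steps. Trifluoromethyl in place of chloro gives a 1.5-fold lower number from compound 2 to compound 4 (0.17 log units; within the scatter) among the phenyl compounds, and this step cannot be told apart from the same exchange among the methyl compounds: the same change on two cores in this assay, a 1.8-fold higher number (0.26 log units; within the scatter) from compound 1 to compound 3 and a 1.5-fold lower number (0.17 log units; within the scatter) from compound 2 to compound 4, 2.6-fold (0.42 log units) apart, within the scatter of two such steps.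

On these data alone, whether a benzyl group or an acetyl group on that nitrogen would give a step of similar size remains open. So does the effect of a longer chain on either core.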